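The source may report more compounds than this note shows. Statements on the series, on what has been measured and on what is new or still open speak of the compounds shown alone.

Of the compounds shown here, three sharing one core have been measured in a functional assay on U-87MG ATCC cells (Homo sapiens) for cytotoxicity, read by MTT assay, with a stated time of 72 h; a lower number here means a stronger inhibitor, a higher number a weaker inhibitor. Compound 1 `CN(C)CCn1cnnc1-c1cc(Oc2ccc(NC(=O)N/N=C/c3ccc(Cl)cc3Cl)cc2F)ccn1` gives 2330 nM. Compound 2 `COc1ccc(/C=N/NC(=O)Nc2ccc(Oc3ccnc(-c4nncn4CCN(C)C)c3)c(F)c2)c(OC)c1` gives 12600 nM, and compound 3 `CN(C)CCn1cnnc1-c1cc(Oc2ccc(NC(=O)N/N=C/c3ccc(O)c(Br)c3)cc2F)ccn1` gives 12400 nM. Among these three numbers compound 3 stands second highest, close to compound 2 and well apart from compound 1; the steps measure a 5.4-fold higher number from compound 1 to compound 2 (0.73 log units; beyond the scatter), a 5.3-fold higher number from compound 1 to compound 3 (0.73 log units; beyond the scatter) and a 1.0-fold lower number from compound 2 to compound 3 (0.01 log units; within the scatter).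

Compound 4 `CN(C)CCn1cnnc1-c1cc(Oc2ccc(NC(=O)N/N=C/c3ccccc3)cc2F)ccn1` has not yet been measured. It differs from compound 3 in one place: phenyl in place of 3-bromo-4-hydroxyphenyl on a carbon with a double bond to nitrogen. The two steps that bear on this change both swap the group on the carbon with a double bond to nitrogen, and both moved the number by a modest amount away from compound 1, while the swap between compound 2 and compound 3 left the number unchanged within the scatter. Among the compounds with values here, a plain phenyl is a third variation at this same place, and no measured step shows how the number behaves when the substituents are removed altogether. The expectation is therefore a step of a 1.8-fold lower number from compound 3 to compound 4 (0.25 log units; within the scatter), that is, little change beyond the scatter, with wide uncertainty. For compound 4 the estimate in this assay is 7000 nM, expected to lie between 2000 nM and 25000 nM.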

Compound 4, half-maximal inhibitory concentration: 2250 nM
Compound 4: middle estimate off by 3.1-fold (0.49 log units), on the high side; measured number inside the range.
By their numbers in this assay, from the lowest: compounds 4 and 1 (each within the scatter of the next); then compounds 3 and 2 (each within the scatter of the next).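

The bare phenyl shows that the ring on the carbon with a double bond to nitrogen needs no substituent to reach the lowest numbers seen in this assay: the change gives a 5.5-fold lower number from compound 3 to compound 4 (0.74 log units; beyond the scatter) and a 5.6-fold lower number from compound 2 to compound 4 (0.75 log units; beyond the scatter). Within the data shown here, the comparison with the dichloro compound gives a 1.0-fold lower number from compound 1 to compound 4 (0.02 log units; within the scatter), so the two chlorines show no measurable gain over plain phenyl, whereas the earlier compounds could have suggested that they were what set compound 1 apart. Across these four compounds, then, the substituents on this ring never lower the number: those of compound 1 leave it in place, while those of compound 2 and compound 3 raise it, and no measurement at hand explains this difference.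

Going by these compounds, each of those two raising groups differs from phenyl by more than one substituent, so it remains open whether the bromine, the hydroxyl or one methoxy alone accounts for the rise. Also open, on these data alone, is how this position would respond to an amine or a carboxylic acid on the ring, or to a longer alkyl chain in place of the ring.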